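The source may hold more compounds than are shown below. What is called first, only, known or untested is meant among the compounds shown, and "the series" means these compounds.

Measured compounds in a functional assay on K562 cells (Homo sapiens) for inhibition, with a stated time of 48 h; on this read-out higher numbers stand for lower toxicity in this test and lower numbers for higher toxicity in this test:
compound 1 `COc1ccc(N(CC(=O)NCCC[Te]c2ccccc2)C(=O)CNC(=O)OC(C)(C)C)cc1`: < 100000 nM.
compound 2 `COc1ccc(N(CC(=O)NCCC[Te]c2ccccc2)C(=O)CCSC2=C(C)C(=O)c3ccccc3C2=O)cc1`: < 100000 nM.
compound 3 `CC1=C(SCCC(=O)OCC(=O)NCCC[Te]c2ccccc2)C(=O)c2ccccc2C1=O`: < 100000 nM.

For compound 1 the value in this assay is a limit of the assay and not a number. The same holds for compound 2. It holds for compound 3 as well; all three sit at the limit of < 100000 nM in this assay, at which 3 of the 3 values shown sit. No value in this set separates compound 1 from the other two.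

Compound 4 `COc1ccc(N(CC(=O)NCCC[Te]c2ccccc2)C(=O)c2ccccc2)cc1` differs from compound 1 by phenyl in place of ((tert-butoxycarbonyl)amino)methyl on a carbonyl carbon. Going by the values given here, no measured pair shows what such a change does, and no step is resolved beyond a limit; the expectation for this assay is therefore no movement beyond the scatter, the step that the limit leaves unreadable from compound 1 to compound 4 being estimated essentially flat. Compound 4 is accordingly expected at 30000 nM, within 5000 nM to 100000 nM, most likely again reported only as a limit.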

Compound 4, concentration lethal to 50% of the cells: < 100000 nM
Compound 4: only a limit was reported; the forecaster's own chance of this, stated with the estimate: 80%; the middle value is on the limit's open side.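

In this assay compound 4 gives < 100000 nM, a limit of the assay and not a number. No step from compound 1 to compound 4 can be read: the limit of < 100000 nM in this assay, at which 4 of the 4 values shown sit.

The compounds shown leave open what phenyl in place of ((tert-butoxycarbonyl)amino)methyl on a carbonyl carbon does to this read-out.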